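Replacing hydroxy by methylamino on a guanine-like core

This account rests on a few compounds, and the source may have more. Where it says the series, first, only, none or still open, it means among the compounds named here.

Measured so far:
- compound 1 `Nc1nc2c(nc(I)n2COCCO)c(=O)[nH]1` gives 39 ug/mL
- compound 2 `Nc1nc2c(nc(O)n2COCCO)c(=O)[nH]1` gives > 500 ug/mL

Compound 1 `Nc1nc2c(nc(I)n2COCCO)c(=O)[nH]1` carries iodo and in a functional assay on L1210 cells (Mus musculus) for inhibition (on this read-out higher numbers stand for weaker inhibition and lower numbers for stronger inhibition), compound 1 gives 39 ug/mL. Compound 2 `Nc1nc2c(nc(O)n2COCCO)c(=O)[nH]1` carries hydroxy instead, and for compound 2 only the assay limit > 500 ug/mL is known (the limit of > 500 ug/mL in this assay, at which 1 of the 2 values shown sits), not a number. Among the compounds with values here, the one measured step, an at least 12-fold higher number from compound 1 to compound 2 (1.10 log units; beyond the scatter), is the only comparison available. Compound 3 `CNc1nc2c(=O)[nH]c(N)nc2n1COCCO` is the next compound: methylamino in place of hydroxy on an aromatic carbon. Within the data shown here, this change undoes the hydroxy of compound 2 and brings in a different group, so the step from compound 2 may partly reverse the loss seen in an at least 12-fold higher number from compound 1 to compound 2 (1.10 log units; beyond the scatter), though no measured compound carries methylamino. Compound 3 is therefore expected to show a lower number than the limit of compound 2, estimated at 250 ug/mL with a range from 50 ug/mL to 1000 ug/mL. The expected step is an at least 2.0-fold lower number from compound 2 to compound 3 (0.30 log units; that floor lies within the scatter).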

Compound 3, concentration for 50% inhibition: > 500 ug/mL
Compound 3 was reported as a limit; the forecaster's own chance of this, stated with the estimate: 45%; middle value at least 2.0-fold (0.30 log units) from the limit.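

In this assay compound 3 gives > 500 ug/mL, which is a limit of the assay and not a number. Replacing iodo with methylamino gives an at least 12-fold higher number from compound 1 to compound 3 (1.10 log units; beyond the scatter), so this second replacement shows no readable recovery from the loss seen with hydroxy, which was an at least 12-fold higher number from compound 1 to compound 2 (1.10 log units; beyond the scatter). The step between compound 2 and compound 3 cannot be read, as both stop at the same assay limit: the limit of > 500 ug/mL in this assay, at which 2 of the 3 values shown sit.

As far as these compounds go, it remains open whether the measurable inhibition of compound 1 depends on iodo specifically or would also appear with bromo or chloro on this aromatic carbon. The compounds shown also do not tell how a plain hydrogen or a dimethylamino group would behave here, or how far beyond the limit compound 2 and compound 3 really lie.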